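Notes on the amide ring in the shared core series

The source may hold more compounds than are shown below. What is called first, only, known or untested is meant among the compounds shown, and "the series" means these compounds.

Three measured compounds share one core and differ only in the ring on the carbonyl carbon of the amide. Compound 1 `CCN1CCN(c2cc(C)c3cc(NC(=O)c4ccccc4F)ccc3n2)CC1` carries a 2-fluorophenyl there; in a functional assay on MCF7 cells (Homo sapiens) for antiproliferative activity, read by MTT assay, with a stated time of 72 h (a higher number here means a weaker inhibitor, a lower number a stronger inhibitor), compound 1 gives 32600 nM. Compound 2 `CCN1CCN(c2cc(C)c3cc(NC(=O)c4cccc(F)c4)ccc3n2)CC1`, with 3-fluorophenyl, gives 8920 nM. Compound 3 `CCN1CCN(c2cc(C)c3cc(NC(=O)c4ccc(F)c(F)c4)ccc3n2)CC1`, with 3,4-difluorophenyl, gives 5230 nM, the lowest of the three numbers, though the gap a 1.7-fold lower number from compound 2 to compound 3 (0.23 log units; within the scatter) is within the scatter, so compound 2 and compound 3 cannot be separated. The steps of a 3.7-fold lower number from compound 1 to compound 2 (0.56 log units; beyond the scatter) and a 6.2-fold lower number from compound 1 to compound 3 (0.79 log units; beyond the scatter) are both beyond the scatter and both modest.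

Compound 4 `CCN1CCN(c2cc(C)c3cc(NC(=O)c4ccc(Br)cc4)ccc3n2)CC1` is the next member: 4-bromophenyl in place of 3,4-difluorophenyl on a carbonyl carbon. For the measured compounds named here, no measured step replaces fluorine by bromine, and none has a ring with a single substituent other than fluorine. Going by the values given here, the nearest precedent is a 1.7-fold lower number from compound 2 to compound 3 (0.23 log units; within the scatter), where adding one fluoro to the ring gave a step within the scatter; the two larger steps concern only the 2-fluorophenyl of compound 1. A 4-bromophenyl is therefore expected to land near compound 3, and the estimated change a 1.0-fold lower number from compound 3 to compound 4 (0.02 log units; within the scatter) is not beyond the scatter. Compound 4 is estimated at 5000 nM, with a range from 1500 nM to 16000 nM.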

Compound 4, half-maximal inhibitory concentration: 5940 nM
The estimate for compound 4 lay 1.2-fold (0.07 log units) below the measured number; measured number inside the range.
By their numbers in this assay, from the lowest: compounds 3, 4 and 2 (each within the scatter of the next); then compound 1.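

In this assay, for the compounds shown here, the 4-bromophenyl is the first ring on the carbonyl carbon to carry no fluorine, yet a 1.1-fold higher number from compound 3 to compound 4 (0.06 log units; within the scatter) and a 1.5-fold lower number from compound 2 to compound 4 (0.18 log units; within the scatter) leave compound 2, compound 3 and compound 4 unseparated. Fluorine on the ring is therefore not required for numbers in this range, and a single bromo group serves as well as the 3-fluorophenyl or the 3,4-difluorophenyl. Compound 1 now stands apart from all three other compounds, with a 5.5-fold lower number from compound 1 to compound 4 (0.74 log units; beyond the scatter) adding a third step beyond the scatter, though still a modest one, and no measurement shown bears on why these rings give such similar numbers or why the 2-fluorophenyl differs.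

The rings shown are all phenyl rings carrying fluoro or bromo groups, so it stays open whether an amine, a carboxylic acid, a methoxy group or a saturated cyclohexyl ring on the carbonyl carbon would leave the number in this range. Going by these compounds, it also stays open whether a 2-bromophenyl would match compound 1 or fall with the other three compounds.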